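The source may hold more compounds than are shown below. What is called first, only, known or untested is meant among the compounds shown, and "the series" means these compounds.

Measured so far in a functional assay on HepG2 cells (Homo sapiens) for antiproliferative activity, read by MTT assay, with a stated time of 24 h (on this read-out higher numbers stand for weaker inhibition and lower numbers for stronger inhibition), are three compounds:
- compound 1 `COc1cc(OC)c(-c2coc3cc(OCc4ccccc4)ccc3c2=O)cc1OC` at 1320 nM
- compound 2 `COc1cc(OC)c(-c2coc3cc(OCc4ccccc4C)ccc3c2=O)cc1OC` at 1860 nM
- compound 3 `COc1cc(OC)c(-c2coc3cc(OCc4cccc(Cl)c4)ccc3c2=O)cc1OC` at 750 nM

Compound 3 sits within the scatter of compound 1 but stands apart from compound 2, the gap being (a 2.5-fold lower number from compound 2 to compound 3 (0.39 log units; beyond the scatter)) in this small set.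

Compound 4 `COc1cc(OC)c(-c2coc3cc(OCc4ccccc4Br)ccc3c2=O)cc1OC` has not yet been measured. It carries 2-bromophenyl in place of 3-chlorophenyl on a saturated chain carbon bound to an oxygen on an aromatic ring, so 3-chlorobenzyl becomes 2-bromobenzyl.

Among the measured compounds shown here, three measured steps bear on this change. Starting from compound 1, adding chloro gave a small step (a 1.8-fold lower number from compound 1 to compound 3 (0.25 log units; within the scatter)) and adding methyl gave another (a 1.4-fold higher number from compound 1 to compound 2 (0.15 log units; within the scatter)), both within the scatter. Compound 2, with its 2-methylphenyl, is the closest available comparison for 2-bromophenyl, and its step to compound 3 (a 2.5-fold lower number from compound 2 to compound 3 (0.39 log units; beyond the scatter)) is the only one beyond the scatter, and modest at that. For the measured compounds named here, no bromo compound has been measured, so this comparison is only a rough guide.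

The step expected in this assay is small and toward a higher number (a 1.7-fold higher number from compound 3 to compound 4 (0.24 log units; within the scatter)), with no clear change beyond the scatter anticipated. For compound 4 the estimated value is 1300 nM with an expected range from 600 nM to 2800 nM in this assay.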

Compound 4, half-maximal inhibitory concentration: 2180 nM
Compound 4: the middle estimate sits 1.7-fold (0.22 log units) below what was measured, within the range that was stated.
By their numbers in this assay, from the lowest: compounds 3, 1, 2 and 4 (each within the scatter of the next, the first and the last beyond it).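

In this assay, replacing 3-chlorobenzyl with 2-bromobenzyl gives a modest step beyond the usual scatter (a 2.9-fold higher number from compound 3 to compound 4 (0.46 log units; beyond the scatter)), the largest single-place step among these compounds. The two compounds named with a 2-substituted phenyl cannot be told apart (a 1.2-fold higher number from compound 2 to compound 4 (0.07 log units; within the scatter)), and both stand apart from compound 3, which suggests that, in this small set, the 3-chloro compound differs from the 2-substituted pair. Compound 1, with a plain benzyl and no substituent, goes against any sharper reading, since bromo in place of hydrogen stays within the scatter (a 1.7-fold higher number from compound 1 to compound 4 (0.22 log units; within the scatter)), as do its steps to compounds 2 and 3.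

No measurement here explains why these compounds differ. A matched pair of 2-chlorobenzyl and 3-bromobenzyl would help separate the place of the group from the identity of the halogen, while a benzyl carrying an amine or a carboxylic acid would show how this position responds to a very different kind of group.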